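Working notes on cytotoxicity for compounds 1 to 4

The source may report more compounds than this note shows. Statements on the series, on what has been measured and on what is new or still open speak of the compounds shown alone.

Compound 1 `CCOC(=O)c1c(-c2cccc(OC)c2)[nH]c2cc(F)cc(F)c2c1=O` and compound 2 `CCOC(=O)c1c(-c2cccc(Oc3ccccc3)c2)[nH]c2cc(F)cc(F)c2c1=O` share one core and differ only at the pendant ring, where the change is phenyl in place of methyl on an oxygen on an aromatic ring. In an ADME assay on BJ cells (Homo sapiens) for cytotoxicity, read by luminescence, with a stated time of 72 h (a higher number here means that more compound is needed for the effect, a lower number that less compound is needed), compound 1 gives > 21500 nM, which is a limit of the assay and not a number. In this assay compound 2 gives > 21500 nM, again a limit of the assay. The step that the two limits leave unreadable from compound 1 to compound 2 therefore cannot be sized because the limit of > 21500 nM in this assay, at which 3 of the 3 values shown sit, holds both ends of it.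

Compound 3 `CCOC(=O)c1c(-c2cccc(OC)c2)[nH]c2cc(OC)c(F)cc2c1=O` keeps the methoxy-bearing pendant ring of compound 1 on a different core; the difference between the two cores is not broken down here. In this assay compound 3 gives > 21500 nM, a limit of the assay. Compound 4 `CCOC(=O)c1c(-c2cccc(Oc3ccccc3)c2)[nH]c2cc(OC)c(F)cc2c1=O` has not been measured; it differs from compound 3 by phenyl in place of methyl on an oxygen on an aromatic ring, the same change as that between compound 1 and compound 2, at the same place.

For compound 4 the expected step that the limit leaves unreadable from compound 3 to compound 4 is essentially nil, an estimate that rests on the earlier step that the two limits leave unreadable from compound 1 to compound 2 being unreadable and on all three measured values sitting at the limit of > 21500 nM in this assay, at which 3 of the 3 values shown sit. Compound 4 is accordingly expected in this assay to give about 30000 nM, most probably reported once more only as a limit, with an estimated range from 15000 nM to 100000 nM.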

Compound 4, half-maximal effective concentration: > 21500 nM
Compound 4 gave a limit, no number; the forecaster's own chance of this, stated with the estimate: 85%; the middle value does not contradict the limit.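

Compound 4 gives > 21500 nM in this assay, again a limit of the assay and not a number. No step can be read from compound 3 to compound 4 because both compounds sit at the same limit: the limit of > 21500 nM in this assay, at which 4 of the 4 values shown sit.

The compounds shown leave open at what concentration any of them takes effect in this assay, and whether methoxy to phenoxy shifts that concentration on either core.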